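Cyclic urea series: aryl swap next to the core

The compounds below may be only part of what the source reports. "The series", "measured", "known", "first", "only" and "open" are said of these compounds alone.

Measured so far:
compound 1 `COc1cccc(N2CCNC(=O)N2)n1`: 3500 nM
compound 2 `O=C1NCCN(c2cccc(-c3cccs3)n2)N1`: 37000 nM

Among the compounds with values here, in a functional assay on cells for inhibition of Polyunsaturated fatty acid 5-lipoxygenase (Homo sapiens) (on this read-out higher numbers stand for weaker inhibition and lower numbers for stronger inhibition), compound 2 gives the higher of the two numbers, the only neighbour being compound 1. Within the data shown here, the one measured step, an 11-fold higher number from compound 1 to compound 2 (1.02 log units; beyond the scatter), does not cover the present change, which is pyridin-2-yl in place of thiophen-2-yl on an aromatic carbon to give compound 3 `O=C1NCCN(c2cccc(-c3ccccn3)n2)N1`. Two aromatic rings of similar size are exchanged here, so no step beyond the scatter is expected, though the direction is open. Compound 3 is therefore estimated at 25000 nM (range 6000 nM to 80000 nM), a step of a 1.5-fold lower number from compound 2 to compound 3 (0.17 log units; within the scatter).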

Compound 3, half-maximal inhibitory concentration: > 50000 nM
Compound 3: a limit, no number (the forecaster's own chance of this, stated with the estimate: 20%); middle value at least 2.0-fold (0.30 log units) from the limit.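

In this assay compound 3 carries a limit of the assay, not a number: the limit of > 50000 nM in this assay, at which 1 of the 3 values shown sits.

Replacing methoxy with pyridin-2-yl gives an at least 14-fold higher number from compound 1 to compound 3 (1.15 log units; beyond the scatter), so the loss seen with thiophen-2-yl also appears with a second aromatic ring at this position. The exchange of the two aromatic rings gives an at least 1.3-fold higher number from compound 2 to compound 3 (0.13 log units; that floor lies within the scatter), so no order between thiophen-2-yl and pyridin-2-yl can be read.

Going by these compounds, whether an amine or an ethoxy group at this position would keep the number close to that of compound 1 stays open.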